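The source may report more compounds than this note shows. Statements on the series, on what has been measured and on what is new or still open speak of the compounds shown alone.

Working notes on the series. In an ADME assay on HOS cells (Homo sapiens) for cytotoxicity (a higher number here means that more compound is tolerated, a lower number that less compound is tolerated), compound 1 `CN(Cc1nc2cccc(CNCCN)c2[nH]1)C1CCCc2cccnc21` gives > 20000 nM, which is a limit of the assay and not a number. Compound 2 `CN(Cc1nc2cccc(CCCN3CCCC3)c2[nH]1)C1CCCc2cccnc21` gives 8200 nM. Compound 3 `CN(Cc1nc2cccc(CCCN3CCCCC3)c2[nH]1)C1CCCc2cccnc21` gives 8700 nM, and the exchange of pyrrolidin-1-yl for piperidin-1-yl amounts to a 1.1-fold higher number from compound 2 to compound 3 (0.03 log units; within the scatter). Compound 4 `CN1CCN(c2cccc3nc(CN(C)C4CCCc5cccnc54)[nH]c23)CC1` carries 4-methylpiperazin-1-yl in place of 3-(piperidin-1-yl)propyl on an aromatic carbon. Going by the values given here, no measured step makes this exact change. The nearest guides are the two steps in the same side chain, an at least 2.4-fold lower number from compound 1 to compound 2 (0.38 log units; beyond the scatter) and an at least 2.2-fold lower number from compound 1 to compound 3 (0.36 log units; beyond the scatter), both of which start from a limit and so fix only a minimum size. The ring exchange between compound 2 and compound 3 shows no step beyond the scatter. No step beyond the scatter is therefore expected in this assay, with any drift expected toward a higher number. The estimated step is a 1.3-fold higher number from compound 3 to compound 4 (0.10 log units; within the scatter). For compound 4 the expected value is 11000 nM, with an estimated range of 5000 nM to 20000 nM.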

Compound 4, half-maximal cytotoxic concentration: 14000 nM
For compound 4 the middle estimate is 1.3-fold (0.10 log units) below the measured one, and the stated range covers the measured number.
By their numbers in this assay, from the lowest: compounds 2, 3 and 4 (each within the scatter of the next). At a limit, above all of these: compound 1.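

In this assay, setting 4-methylpiperazin-1-yl directly on this aromatic carbon in place of the 3-(piperidin-1-yl)propyl chain gives a 1.6-fold higher number from compound 3 to compound 4 (0.21 log units; within the scatter), and the exchange for the 3-(pyrrolidin-1-yl)propyl chain gives a 1.7-fold higher number from compound 2 to compound 4 (0.23 log units; within the scatter), so the propyl chain is not needed to keep the number in this range. The comparison with the ((2-aminoethyl)amino)methyl group gives an at least 1.4-fold lower number from compound 1 to compound 4 (0.15 log units; that floor lies within the scatter), so unlike compounds 2 and 3, compound 4 is not shown to differ beyond the scatter from compound 1. That comparison fixes only a floor because compound 1 is reported as a limit and not a number: the limit of > 20000 nM in this assay, at which 1 of the 4 values shown sits.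

Open, from the compounds shown here alone, is whether the number at this aromatic carbon depends on a side-chain amine at all. A morpholin-4-yl ring or a carboxylic acid at this place would bear on that question, and a chain longer than propyl would show whether the range holds with greater length.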